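Swapping bromo for fluoro on two related cores

The source may hold more compounds than are shown below. What is called first, only, known or untested is meant among the compounds shown, and "the series" means these compounds.

Measured compounds:
- compound 1, `O=C(CSC(=S)N[C@H]1CCOC1=O)Nc1ccc(Br)cc1`: 67400 nM
- compound 2, `O=C(CSC(=S)N[C@H]1CCOC1=O)Nc1ccc(F)cc1`: 67100 nM
- compound 3, `O=C(CSC(=S)N[C@H]1CCOC1=O)Nc1ccc(C(=O)/C=C/c2ccc(Br)cc2)cc1`: 91200 nM

All three were tested in a functional assay on EC9706 cells (Homo sapiens) for cytotoxicity, read by MTT assay, with a stated time of 72 h; on this read-out lower numbers stand for stronger inhibition and higher numbers for weaker inhibition. Compound 1 gives 67400 nM there, and compound 2 gives 67100 nM. The two differ in a single spot: fluoro in place of bromo on an aromatic carbon. That swap made a step of a 1.0-fold lower number from compound 1 to compound 2 (0.00 log units; within the scatter), so the two values are indistinguishable here.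

Compound 3 carries a larger core, and in this assay compound 3 gives 91200 nM. Its value sits close to those of compound 1 and compound 2, within the usual scatter of both. The difference between the core of compound 3 and the core of compound 1 is not broken down here.

Compound 4, `O=C(CSC(=S)N[C@H]1CCOC1=O)Nc1ccc(C(=O)/C=C/c2ccc(F)cc2)cc1`, has not yet been measured. It differs from compound 3 in one spot: fluoro in place of bromo on an aromatic carbon. For the measured compounds named here, the place of the change is described in the same words for both pairs, so this is the same kind of change as the one from compound 1 to compound 2, made on a different core.

Because the earlier swap gave a 1.0-fold lower number from compound 1 to compound 2 (0.00 log units; within the scatter), the step from compound 3 to compound 4 in this assay is expected to be about a 1.0-fold lower number from compound 3 to compound 4 (0.01 log units; within the scatter). Compound 4 is therefore estimated at 90000 nM in this assay, with a range from 45000 nM to 180000 nM.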

Compound 4, half-maximal inhibitory concentration: 46100 nM
Compound 4: the middle estimate sits 2.0-fold (0.29 log units) above what was measured; the range from low to high includes it.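

In this assay, putting fluoro in place of bromo on the larger core gives a 2.0-fold lower number from compound 3 to compound 4 (0.30 log units; within the scatter), so this step cannot be told apart from the ordinary spread of repeated measurements. Set beside the same swap on the smaller core, the new step shows no real disagreement between the two cores: the same change on two cores in this assay, a 1.0-fold lower number (0.00 log units; within the scatter) from compound 1 to compound 2 and a 2.0-fold lower number (0.30 log units; within the scatter) from compound 3 to compound 4, 2.0-fold (0.29 log units) apart, within the scatter of two such steps In this small set, then, the swap carries over in the sense that it makes no difference that can be read on either core, but two pairs of compounds in a single assay do not make a rule for the whole series, and they give no explanation of why the swap behaves this way.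

The compounds shown carry only bromo or fluoro at this place on the aromatic ring, so it remains open whether chloro, a methoxy group, an amine or a carboxylic acid there would move the number beyond the scatter. From the compounds shown here alone, it also remains open whether the swap would stay just as silent on a third core, or in a cell line other than the one used in this assay.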